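Coumarin-type A2b antagonists: para substituent swap on compound 3

The compounds below may be only part of what the source reports. "The series", "measured", "known", "first", "only" and "open" are said of these compounds alone.

Measured so far:
- Compound 1, `CCOc1cccc2cc(-c3ccc(OC)cc3)c(=O)oc12`; in a functional assay on CHO cells for antagonist activity at adenosine receptor A2b (Homo sapiens), read by cAMP accumulation (on this read-out higher numbers stand for weaker inhibition and lower numbers for stronger inhibition), compound 1 sits at the assay limit, > 30000 nM.
- Compound 2, `CCOc1cccc2cc(-c3ccc([N+](=O)[O-])cc3)c(=O)oc12`; in this assay compound 2 sits at the assay limit, > 30000 nM.
- Compound 3, `COc1cccc2cc(-c3ccc([N+](=O)[O-])cc3)c(=O)oc12`; in this assay compound 3 sits at the assay limit, > 30000 nM.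

Compound 3 therefore stands nowhere on a numerical scale: its value is a limit only, as are the other two values shown, all of them at the same limit (the limit of > 30000 nM in this assay, at which 3 of the 3 values shown sit).

Compound 4, `COc1ccc(-c2cc3cccc(OC)c3oc2=O)cc1`, differs from compound 3 by methoxy in place of nitro on an aromatic carbon. Among the compounds with values here, two measured steps bear on the series. The step that the two limits leave unreadable from compound 1 to compound 2 changes the same para position in the opposite sense; the step that the two limits leave unreadable from compound 2 to compound 3 changes the chain on the core oxygen. Neither step can be read, since both ends sit at the limit. Compound 1 already carries the para methoxy that enters in compound 4 and gives only a limit.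

No step beyond the scatter is expected in this assay in either direction. Compound 4 is expected at 50000 nM, between 20000 nM and 200000 nM. The estimated step is a step that the limit leaves unreadable from compound 3 to compound 4, most likely again reported as a limit.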

Compound 4, half-maximal inhibitory concentration: > 30000 nM
Compound 4 ended at the assay's limit; the forecaster's own chance of this, stated with the estimate: 85%; the middle value lies beyond the limit too.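

Neither the step from compound 3 to compound 4 nor the step from compound 1 to compound 4 can be read, as both ends of each step sit at a limit: the limit of > 30000 nM in this assay, at which 4 of the 4 values shown sit.

The compounds shown leave open how large these changes are, and whether any substituent on the shared core gives a numerical value.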